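Fluoro for Chloro: Expecting a Stronger Effect

The compounds below may be only part of what the source reports. "The series", "measured", "known", "first", "only" and "open" are said of these compounds alone.

In a functional assay on the whole organism (strain NMRI) with Mus musculus as the target, with a stated time of 60 min, at a dose of 10 mg/kg by the intraperitoneal route (a lower number here means a weaker effect, a higher number a stronger effect of the compound at the dose given), three compounds have been measured so far:

Compound 1 `Clc1ccc(Cc2nnc(SCc3ccccc3)[nH]2)c(Oc2ccccc2Cl)c1` gives 122%.
Compound 2 `Fc1ccccc1Oc1cc(Cl)ccc1Cc1nnc(SCc2ccccc2)[nH]1` gives 169%.
Compound 3 `CCOc1nnc(Cc2ccc(Cl)cc2Oc2ccccc2Cl)[nH]1` gives 122%.

Compound 2 differs from compound 1 by fluoro in place of chloro on an aromatic carbon, and this change made a step of a number 47 percentage points higher from compound 1 to compound 2 (beyond the scatter). Compound 3 differs from compound 1 by ethoxy in place of benzylsulfanyl on an aromatic carbon, a change that gave no change at the digits printed from compound 1 to compound 3 (within the scatter), so compound 3 and compound 1 stand together at the lower end of the three numbers.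

Compound 4 `CCOc1nnc(Cc2ccc(Cl)cc2Oc2ccccc2F)[nH]1` has not been measured. It differs from compound 3 by fluoro in place of chloro on an aromatic carbon, the same change at the same place as the one already seen. Among the measured compounds shown here, a step of about a number 38 percentage points higher from compound 3 to compound 4 (beyond the scatter) is therefore expected, resting on the one earlier step, a number 47 percentage points higher from compound 1 to compound 2 (beyond the scatter), with no second example to confirm it. Compound 4 is expected to give roughly 160%, plausibly between 125% and 200%.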

Compound 4, a percentage reported as activity, at one dose (the size of the read-out at that dose, not a potency): 116%
Compound 4: middle estimate off by 44 percentage points, on the high side, and the stated range ends above it.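

Replacing 2-chlorophenoxy with 2-fluorophenoxy did not carry over from one core to the other, for with ethoxy in the molecule it gave a number 6 percentage points lower from compound 3 to compound 4 (within the scatter): the same change on two cores in this assay, a number 47 percentage points higher (beyond the scatter) from compound 1 to compound 2 and a number 6 percentage points lower (within the scatter) from compound 3 to compound 4, 53 percentage points apart, beyond the scatter of two such steps

Seen from the other side, ethoxy in place of benzylsulfanyl gave a number 53 percentage points lower from compound 2 to compound 4 (beyond the scatter), whereas the same change showed no difference between compound 1 and compound 3: the same change on two cores in this assay, no change at the digits printed (within the scatter) from compound 1 to compound 3 and a number 53 percentage points lower (beyond the scatter) from compound 2 to compound 4, 53 percentage points apart, beyond the scatter of two such steps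

So the two changes do not add up independently in these four compounds, but this rests on a single set of two cores and does not show why the steps differ.

As far as these compounds go, it remains open whether the high value of compound 2 needs benzylsulfanyl specifically, and how fluoro would behave with an amine or a longer chain in that place. A read-out at one dose also tells only of a stronger or weaker effect at that dose.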